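The source may report more compounds than this note shows. Statements on the series, on what has been measured and on what is new or still open speak of the compounds shown alone.

In an ADME assay on HOS cells (Homo sapiens) for cytotoxicity (on this read-out higher numbers stand for weaker inhibition and lower numbers for stronger inhibition), compound 1 (`O=C1c2ccc(O)c(O)c2C(=O)N1Cc1cccc(Cl)c1`) gives 13300 nM and compound 2 (`O=C1c2ccc(O)c(O)c2C(=O)N1Cc1cccc(Br)c1`) gives 11400 nM, so compound 2 stands level with compound 1 within the scatter. Compound 3 (`O=C1c2ccc(O)c(O)c2C(=O)N1Cc1cccc(I)c1`) differs from compound 2 by iodo in place of bromo on an aromatic carbon, with iodo in place of bromo on an aromatic carbon, meta to a large group. Among the compounds with values here, the only measured step bearing on this is a 1.2-fold lower number from compound 1 to compound 2 (0.07 log units; within the scatter), which put bromo in place of chloro at the same place. No change beyond the scatter is therefore expected in this assay. The expected step is a 1.1-fold lower number from compound 2 to compound 3 (0.04 log units; within the scatter). Compound 3 is estimated at 10500 nM, within a range of 5500 nM to 20000 nM.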

Compound 3, half-maximal inhibitory concentration: 12000 nM
Beside the measured number, compound 3's estimate is 1.1-fold (0.06 log units) below it, and the stated range covers the measured number.
By their numbers in this assay, from the lowest: compounds 2, 3 and 1 (each within the scatter of the next).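

In this assay, the change from 3-bromophenyl to 3-iodophenyl gives a 1.1-fold higher number from compound 2 to compound 3 (0.02 log units; within the scatter) and the change from chloro to iodo gives a 1.1-fold lower number from compound 1 to compound 3 (0.04 log units; within the scatter) in the same series. Chloro, bromo and iodo at this place on the aromatic ring therefore stand level, and the halogen series shows no trend across compound 1, compound 2 and compound 3. No measured evidence bears on this result.

As far as these compounds go, whether an amine, a carboxylic acid or a methoxy group at this place would stay level remains open. The compounds shown also leave open how other places on this ring respond.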